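This account rests on a few compounds, and the source may have more. Where it says the series, first, only, none or still open, it means among the compounds named here.

Measured so far:
compound 1, `CC(NC(=O)CN)C(=O)N(C)c1ccc(Cl)cc1C(=O)c1ccccc1Cl`: 8.5 mg/kg
compound 2, `CN1CCN(CC(=O)NCC(=O)N(C)c2ccc(Cl)cc2C(=O)c2ccccc2Cl)CC1`: > 100 mg/kg
compound 3, `NCC(=O)NCC(=O)Nc1ccc([N+](=O)[O-])cc1C(=O)c1ccccc1`: 24.8 mg/kg

All three were tested in a functional assay on the whole organism with Mus musculus as the target, in the rotarod test; a higher number here means that more compound is needed for the effect, a lower number that less compound is needed. Compound 1 gives 8.5 mg/kg and compound 3 gives 24.8 mg/kg in this assay. Going by these compounds, for compound 2 this assay reports only a limit, > 100 mg/kg, so its true value is unknown; it sits at the limit of > 100 mg/kg in this assay, at which 1 of the 3 values shown sits. Compound 4, `CN(C(=O)CNC(=O)CN1CCCCC1)c1ccc(Cl)cc1C(=O)c1ccccc1Cl`, has not yet been measured. It differs from compound 2 in one place: piperidin-1-yl in place of 4-methylpiperazin-1-yl on a saturated chain carbon bound to a carbonyl carbon. Among the compounds with values here, no step between two measured compounds shows what this change does, and compound 2 itself gives only a limit, so the size of the step is open. A step toward a lower dose is expected, an at least 1.6-fold lower number from compound 2 to compound 4 (0.22 log units; that floor lies within the scatter), though a limit again is possible. Compound 4 is expected to give about 60 mg/kg in this assay, within a range from 15 mg/kg to 200 mg/kg.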

Compound 4, dose for half-maximal effect: > 100 mg/kg
Compound 4: a limit, no number; the forecaster's own chance of this, stated with the estimate: 40%; middle value at least 1.6-fold (0.22 log units) from the limit.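

In this assay, within the data shown here, compound 2 and compound 4 both stop at a limit, so no step between them can be read: the limit of > 100 mg/kg in this assay, at which 2 of the 4 values shown sit. Going by these compounds, whether piperidin-1-yl in place of 4-methylpiperazin-1-yl changes the dose needed, and by how much, stays open.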